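Aryl swap on the amide nitrogen: compound 1 to compound 4

The source may hold more compounds than are shown below. What is called first, only, known or untested is meant among the compounds shown, and "the series" means these compounds.

Compound 1 `COc1ccc2c(=O)c(/C=C/C(=O)Nc3cccc(Cl)c3)coc2c1` gives 1100000 nM in an ADME assay on HepG2 2.2.15 cells (Homo sapiens) for cytotoxicity, read by MTT assay, with stated times of 48 h and 9 days (on this read-out higher numbers stand for lower toxicity in this test and lower numbers for higher toxicity in this test), the highest of the three numbers available in the series. Compound 2 `COc1ccc2c(=O)c(/C=C/C(=O)Nc3ccccc3Cl)coc2c1` sits right beside it with 1010000 nM; the step of a 1.1-fold lower number from compound 1 to compound 2 (0.04 log units; within the scatter) stays within the scatter, so neither can be ranked against the other. Compound 3 `COc1ccc(CNC(=O)/C=C/c2coc3cc(OC)ccc3c2=O)cc1` stands apart at 43000 nM, reached through a 26-fold lower number from compound 1 to compound 3 (1.41 log units; beyond the scatter) and, from the other chlorophenyl, through a 23-fold lower number from compound 2 to compound 3 (1.37 log units; beyond the scatter).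

Compound 4 `COc1ccc2c(=O)c(/C=C/C(=O)Nc3ccccc3C)coc2c1` has not yet been measured. Relative to compound 1 it differs as follows: 2-methylphenyl in place of 3-chlorophenyl on an amide-type nitrogen. Among the compounds with values here, the one measured step that bears on this kind of change is the aryl-to-aryl swap a 1.1-fold lower number from compound 1 to compound 2 (0.04 log units; within the scatter), which stayed within the scatter. The two large steps, a 26-fold lower number from compound 1 to compound 3 (1.41 log units; beyond the scatter) and a 23-fold lower number from compound 2 to compound 3 (1.37 log units; beyond the scatter), both have 4-methoxybenzyl entering and so describe a different kind of change; they carry little weight here. The expected step in this assay is therefore a 1.1-fold lower number from compound 1 to compound 4 (0.04 log units; within the scatter), none beyond the scatter. For compound 4 the estimate in this assay is 1000000 nM, with a range from 400000 nM to 2500000 nM.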

Compound 4, half-maximal cytotoxic concentration: 59700 nM
Compound 4: middle estimate off by 17-fold (1.22 log units), on the high side, outside the stated range (below it).
By their numbers in this assay, from the lowest: compounds 3 and 4 (each within the scatter of the next); then compounds 2 and 1 (each within the scatter of the next).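

In this assay, the aryl group on the amide-type nitrogen is not interchangeable, as the within-scatter swap between the two chlorophenyl compounds had suggested: an 18-fold lower number from compound 1 to compound 4 (1.27 log units; beyond the scatter) shows that one aryl-for-aryl change can be as consequential as the change to 4-methoxybenzyl. The sharpest reading is a 17-fold lower number from compound 2 to compound 4 (1.23 log units; beyond the scatter), where methyl in place of chloro on an aromatic carbon is the only difference, so the large step needs no change of the amide-nitrogen attachment from aryl to benzyl. In addition, a 1.4-fold higher number from compound 3 to compound 4 (0.14 log units; within the scatter) places the 2-methylphenyl and 4-methoxybenzyl compounds within the scatter of each other, so among these four compounds the two with chlorine give the high numbers and the two without give the low numbers, with no compound going against that split.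

As far as these compounds go, whether the high numbers are specific to chloro or would also hold with bromo, fluoro or an amine on the same aromatic carbon remains open. Nothing available explains why the exchange of chloro for methyl carries so large a step.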